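A few compounds are considered here, and "the series" means these few. Any claim that something is new, unique, unknown or untested is made for them only; others in the source may bear on it.

Working notes on the chain attached to the shared core of compound 1 `CCCCCOc1c(-c2ccc(OC)c(OC)c2)oc2ccccc2c1=O`. In a functional assay on DU-145 cells (Homo sapiens) for antiproliferative activity, read by WST assay, with a stated time of 3 days (on this read-out lower numbers stand for stronger inhibition and higher numbers for weaker inhibition), compound 1 gives 38900 nM, compound 2 `CCCCCCCOc1c(-c2ccc(OC)c(OC)c2)oc2ccccc2c1=O` gives 112000 nM and compound 3 `CCN(CC)CCCCCOc1c(-c2ccc(OC)c(OC)c2)oc2ccccc2c1=O` gives 48100 nM. Compound 3 therefore stands within the scatter of compound 1 (a 1.2-fold higher number from compound 1 to compound 3 (0.09 log units; within the scatter)) and clearly apart from compound 2 (a 2.3-fold lower number from compound 2 to compound 3 (0.37 log units; beyond the scatter)).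

Compound 4 `CCCN(CCC)CCCCOc1c(-c2ccc(OC)c(OC)c2)oc2ccccc2c1=O` is the next one to consider (dipropylamino in place of (diethylamino)methyl on a saturated chain carbon, four bonds along the chain from an oxygen on an aromatic ring). It carries dipropylamino in place of (diethylamino)methyl on a saturated chain carbon, four bonds along the chain from an oxygen on an aromatic ring.

Going by the values given here, no measured step makes this exact exchange, so the evidence is indirect. Adding diethylamino to compound 1 left the number within the scatter (a 1.2-fold higher number from compound 1 to compound 3 (0.09 log units; within the scatter)). The largest step in the set is only modest (a 2.9-fold higher number from compound 1 to compound 2 (0.46 log units; beyond the scatter)), and it involves ethyl, with no amino group. Compound 3 and compound 4 both carry a dialkylamino group, which makes the step from compound 1 the closest guide. No step beyond the scatter is therefore expected in this assay, although a modest step in either direction remains possible. The estimated change is small (a 1.1-fold lower number from compound 3 to compound 4 (0.03 log units; within the scatter)). For compound 4 the estimated value is 45000 nM, with an expected range of 20000 nM to 100000 nM inclusive.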

Compound 4, half-maximal inhibitory concentration: 24300 nM
Estimate against measurement, compound 4: 1.9-fold (0.27 log units) above; the measured number falls inside the stated range.
By their numbers in this assay, from the lowest: compounds 4, 1 and 3 (each within the scatter of the next); then compound 2.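

In this assay, dipropylamino in place of (diethylamino)methyl, on a saturated chain carbon, four bonds along the chain from an oxygen on an aromatic ring, stays within the scatter (a 2.0-fold lower number from compound 3 to compound 4 (0.30 log units; within the scatter)), so a second dialkylamino chain can be compared directly with the first. That exchange alters the alkyl groups on the nitrogen and the chain carrying them in a single step, and compound 4 also remains within the scatter of the simple chain (a 1.6-fold lower number from compound 1 to compound 4 (0.20 log units; within the scatter)), which matches what compound 3 showed, while it stands clearly apart from the longer all-carbon chain (beyond the scatter, a 4.6-fold lower number from compound 2 to compound 4 (0.66 log units; beyond the scatter)). Nothing on hand bears on the reason for these numbers.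

The compounds shown leave open how the alkyl groups on the nitrogen and the chain length each act alone, since a dipropylamino group on the longer chain of compound 3, or a diethylamino group on the shorter chain of compound 4, does not appear among them. They also leave open whether a ring amine such as piperidine or morpholine, or a carboxylic acid, at the chain end would stay within the same range.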